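A few compounds are considered here, and "the series" means these few. Any claim that something is new, unique, unknown or untested is made for them only; others in the source may bear on it.

Three compounds sharing a core were examined in an ADME assay on Vero cells (Chlorocebus sabaeus) for cytotoxicity; on this read-out higher numbers stand for lower toxicity in this test and lower numbers for higher toxicity in this test. Compound 1 `N=C(NO)N/N=C/c1ccc(Cl)cc1` gives > 100000 nM, a limit of the assay rather than a number. Compound 2 `CN(C)c1ccc(/C=N/NC(=N)NO)cc1` gives > 100000 nM, again a limit. Compound 3 `Cc1ccccc1/C=N/NC(=N)NO` gives > 100000 nM, also a limit. The step from compound 1 to compound 2, a step that the two limits leave unreadable from compound 1 to compound 2, cannot be read because of the limit of > 100000 nM in this assay, at which 3 of the 3 values shown sit. Compound 2 therefore stands at the limit, with no number that would place it against the other two. Compound 4 `Cc1ccc(/C=N/NC(=N)NO)cc1` differs from compound 2 by methyl in place of dimethylamino on an aromatic carbon. No measured step can be read, so nothing sets a direction for this change in this assay. Compound 4 is expected to sit at the limit as well, with an estimated step that the limit leaves unreadable from compound 2 to compound 4 and an estimated value of 150000 nM between 50000 nM and 500000 nM.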

Compound 4, half-maximal cytotoxic concentration: > 100000 nM
Compound 4: a limit, no number; the forecaster's own chance of this, stated with the estimate: 85%; the middle value does not contradict the limit.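

Compound 4 gives > 100000 nM, a limit and not a number. The steps to compound 4 from compound 1 and compound 2 therefore cannot be read: the limit of > 100000 nM in this assay, at which 4 of the 4 values shown sit.

The compounds shown leave open whether chloro, dimethylamino or methyl on the shared core makes any difference in this assay.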